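The source may report more compounds than this note shows. Statements on the series, on what has been measured and on what is new or still open speak of the compounds shown alone.

Measured so far in a functional assay on PC-12 cells (Rattus norvegicus) for cytotoxicity, read by MTT assay, with stated times of 2 h and 24 h, tested at 10 uM; a higher number here means a stronger effect of the compound at the concentration tested, a lower number a weaker effect:
- compound 1 `CC(C)c1ccc(-n2nc(-c3ccc(C(F)(F)F)cc3O)nc2-c2ccccc2O)cc1` gives 108%
- compound 2 `Oc1cc(C(F)(F)F)ccc1-c1nc(-c2ccccc2O)n(-c2ccc(C(F)(F)F)cc2)n1` gives 102%
- compound 3 `Oc1cc(C(F)(F)F)ccc1-c1nc(-c2ccccc2O)n(-c2ccccc2C(F)(F)F)n1` gives 92.2%

Compound 3 stands lowest of the three numbers in this assay; its gap to compound 2 is within the scatter, its gap to compound 1 beyond it. Compound 4 `Cc1ccc(-n2nc(-c3ccc(C(F)(F)F)cc3O)nc2-c2ccccc2O)c(C)c1` differs from compound 3 in one place: 2,4-dimethylphenyl in place of 2-(trifluoromethyl)phenyl on an aromatic nitrogen. Going by the values given here, two measured steps bear on this change, both arriving at compound 3: a number 15.8 percentage points lower from compound 1 to compound 3 (beyond the scatter) and a number 9.8 percentage points lower from compound 2 to compound 3 (within the scatter). The group that now leaves, 2-(trifluoromethyl)phenyl on the aromatic nitrogen, was in both cases the one that came in when the number fell, and only the move away from 4-isopropylphenyl was beyond the scatter. The incoming 2,4-dimethylphenyl resembles the 4-isopropylphenyl of compound 1 more than the 4-(trifluoromethyl)phenyl of compound 2, so an upward step is expected, a number 11.8 percentage points higher from compound 3 to compound 4 (beyond the scatter), with a result within the scatter also possible. For compound 4 the value in this assay is estimated at 104%, range 90% to 118%.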

Compound 4, a percentage reported as activity, at one concentration (the size of the read-out at that concentration, not a potency): 106%
Estimate against measurement, compound 4: 2 percentage points below, and the stated range covers the measured number.
By their numbers in this assay, from the lowest: compounds 3, 2, 4 and 1 (each within the scatter of the next, the first and the last beyond it).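

In this assay, 2,4-dimethylphenyl in place of 2-(trifluoromethyl)phenyl on the aromatic nitrogen gives a number 13.8 percentage points higher from compound 3 to compound 4 (beyond the scatter), so a group named with a substituent at 2 does not by itself go with the lower number; among the compounds shown, that number stays with 2-(trifluoromethyl)phenyl alone. Against the other two groups at this position the change reads as a number 4 percentage points higher from compound 2 to compound 4 (within the scatter) and a number 2 percentage points lower from compound 1 to compound 4 (within the scatter), which leaves 2,4-dimethylphenyl, 4-(trifluoromethyl)phenyl and 4-isopropylphenyl unresolved from one another. No measurement at hand says why the group on this nitrogen shifts the number.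

As far as these compounds go, the shift from compound 3 combines two differences on the ring, so it remains open whether a lone 2-methylphenyl or 4-methylphenyl would read the same. Also open, from the compounds shown here alone, is how a phenyl carrying an amine or a carboxylic acid would read at this position.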